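This account rests on a few compounds, and the source may have more. Where it says the series, first, only, none or still open, it means among the compounds named here.

Working notes on the step from compound 3 `N#Cc1ccc(Cn2c3c(c(O)c(C(=O)NCC(=O)O)c2=O)COCC3)c(F)c1` to compound 4 `O=C(O)CNC(=O)c1c(O)c2c(n(Cc3ccc(C(F)(F)F)nc3)c1=O)CCOC2`. In an ADME assay on LLC-PK1 cells (Sus scrofa) for permeability, with a stated time of 3 h, tested at 1 uM (a lower number here means that the compound crosses the layer more slowly, a higher number that the compound crosses the layer faster), compound 3 stands at "not determined" (no result reported), so it offers no number to start from. The structural change is 6-(trifluoromethyl)pyridin-3-yl in place of 4-cyano-2-fluorophenyl on a saturated chain carbon bound to an aromatic nitrogen. The nearest measured points are compound 1 `O=C(O)CNC(=O)c1c(O)c2c(n(Cc3ccc(C(F)(F)F)cc3)c1=O)CCOC2` at 4 10^-6 cm/s and compound 2 `O=C(O)CNC(=O)c1c(O)c2c(n(Cc3ccc(Cl)cc3)c1=O)CCOC2` at 3.6 10^-6 cm/s. Among the compounds with values here, only one measured step bears on the change, and only indirectly: a 1.1-fold lower number from compound 1 to compound 2 (0.05 log units; within the scatter), chloro in place of trifluoromethyl on an aromatic carbon, which stays within the scatter. Within the data shown here, no measured step covers the entry of an aromatic ring with a hetero atom, so that part of the change remains untested. On this evidence, no step beyond the scatter is expected in this assay, in either direction, relative to the two measured compounds. For compound 4 the estimated value is 3 10^-6 cm/s, with an expected range of 1.5 10^-6 cm/s to 6 10^-6 cm/s.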

Compound 4, apparent permeability: < 1.7 10^-6 cm/s
Compound 4: only a limit was reported (the forecaster's own chance of this, stated with the estimate: 10%); middle value at least 1.7-fold (0.24 log units) from the limit.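

In this assay, this place on the saturated chain carbon bound to an aromatic nitrogen now shows a step beyond the scatter: 6-(trifluoromethyl)pyridin-3-yl in place of 4-(trifluoromethyl)phenyl gives an at least 2.3-fold lower number from compound 1 to compound 4 (0.37 log units; beyond the scatter), with the trifluoromethyl kept and a ring with a hetero atom replacing a ring of carbon only. Within the data shown here, the same entering group in place of 4-chlorophenyl gives an at least 2.1-fold lower number from compound 2 to compound 4 (0.32 log units; beyond the scatter), whereas the two carbon-only rings of the earlier compounds stayed within the scatter of each other. The reading for compound 4 is a limit and not a number: the limit of < 1.7 10^-6 cm/s in this assay, at which 1 of the 4 values shown sits.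

Steps from compound 3 cannot be read, and how far compound 4 lies under its limit stays open. As far as these compounds go, whether a pyrimidine ring or a methoxy-substituted pyridine at this place would read like compound 4 also stays open.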